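Extending one side chain on a shared core

The source may hold more compounds than are shown below. What is called first, only, known or untested is meant among the compounds shown, and "the series" means these compounds.

In a functional assay on HeLa cells (Homo sapiens) for inhibition (a higher number here means a weaker inhibitor, a lower number a stronger inhibitor), compound 1 `CC(C)=CCC/C(C)=C/C[C@]12C(=O)CC(=O)[C@](CC=C(C)C)(C[C@@H](CC=C(C)C)C1(C)C)C2=O` gives 11.7 ug/mL and compound 2 `CC(C)=CCC/C(C)=C/C[C@]12C[C@@H](CC=C(C)C)C(C)(C)[C@](CC=C(C)C)(C(=O)CC1=O)C2=O` gives 6.64 ug/mL. These two values lie within the usual scatter of each other, so compound 2 stands level with compound 1, and the numbers cannot separate them.

The next structure is compound 3 `CC(C)=CCC/C(C)=C/C[C@@H]1C[C@@]2(C/C=C(\C)CCC=C(C)C)C(=O)CC(=O)[C@](CC=C(C)C)(C2=O)C1(C)C`. Going from compound 2 to compound 3, the change is 3-methylbut-2-en-1-yl in place of hydrogen on a saturated chain carbon bound to a double-bonded chain carbon. Seen one bond further out, a 3-methylbut-2-en-1-yl chain becomes a 3,7-dimethylocta-2,6-dien-1-yl chain.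

Within the data shown here, no measured pair here shows what a change of this kind does, so the only guide is the level set by compound 1 at 11.7 ug/mL and compound 2 at 6.64 ug/mL. The expected result in this assay is a 1.2-fold higher number from compound 2 to compound 3 (0.08 log units; within the scatter), which is nothing beyond the scatter and has no firm direction. For compound 3 the estimated value is 8 ug/mL, with an expected range from 3.5 ug/mL to 18 ug/mL.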

Compound 3, half-maximal inhibitory concentration: > 20 ug/mL
Compound 3: no number, only a limit; the forecaster's own chance of this, stated with the estimate: 4%; middle value at least 2.5-fold (0.39 log units) away from the limit.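

In this assay, extending this side chain from 3-methylbut-2-en-1-yl to 3,7-dimethylocta-2,6-dien-1-yl gives an at least 3.0-fold higher number from compound 2 to compound 3 (0.47 log units; beyond the scatter), which points toward weaker inhibition. Compound 3 reads > 20 ug/mL, which is a limit of the assay and not a number. With compound 1 and compound 2 level with each other, this is the first step shown that rises beyond the scatter, so adding 3-methylbut-2-en-1-yl on this saturated chain carbon bound to a double-bonded chain carbon is not a neutral change, although the true size of the step stays unknown: the limit of > 20 ug/mL in this assay, at which 1 of the 3 values shown sits.

The compounds shown leave open whether the higher number follows from the extra chain length in general or from this particular unsaturated chain, a question that a fully saturated chain, a plain ethyl group or a chain ending in a carboxylic acid at this place could help to answer. They also leave open whether the same extension on either of the other 3-methylbut-2-en-1-yl chains of the shared core would give a similar step.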